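A few compounds are considered here, and "the series" means these few. Any claim that something is new, unique, unknown or untested is made for them only; others in the source may bear on it.

Of the compounds shown here, three from this series have been tested so far. Compound 1 `CC1=CC[C@H]2[C@@H]1CC=C(C)[C@@H](CC[C@H]1[C@]3(C)CC[C@H](OC(=O)c4ccccc4)C(C)(C)O[C@H]3CC[C@@]1(C)O)C2(C)C` carries a benzoyl group on an oxygen on a saturated carbon, and in a functional assay on MCF7 cells (Homo sapiens) for antiproliferative activity, read by MTT assay, with a stated time of 72 h (a higher number here means a weaker inhibitor, a lower number a stronger inhibitor), compound 1 gives 23100 nM. Compound 2 `CC1=CC[C@H]2[C@@H]1CC=C(C)[C@@H](CC[C@H]1[C@]3(C)CC[C@H](OCc4ccccc4)C(C)(C)O[C@H]3CC[C@@]1(C)O)C2(C)C` differs from it by benzyl in place of benzoyl on that oxygen; for compound 2 this assay reports only a limit, > 50000 nM. That change gave an at least 2.1-fold higher number from compound 1 to compound 2 (0.33 log units; beyond the scatter), a step that reaches (the limit of > 50000 nM in this assay, at which 1 of the 3 values shown sits). Compound 3 `CC1=CC[C@H]2[C@H](CC[C@]2(C)O)C(C)(C)[C@@H]1CC[C@H]1[C@]2(C)CC[C@H](OC(=O)c3ccc(F)cc3)C(C)(C)O[C@H]2CC[C@@]1(C)O` is the third measured compound; in this assay compound 3 gives 33500 nM, which sits as the highest of the two plain numbers, with compound 1 close to it and within the scatter.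

Compound 4 `CC1=CC[C@H]2[C@H](CC[C@]2(C)O)C(C)(C)[C@@H]1CC[C@H]1[C@]2(C)CC[C@H](OC(=O)c3ccccc3F)C(C)(C)O[C@H]2CC[C@@]1(C)O` is not yet measured. Its difference from compound 3 is 2-fluorophenyl in place of 4-fluorophenyl on a carbonyl carbon. Among the measured compounds shown here, no measured step moves a fluorine around an aromatic ring: the only step available exchanges benzyl for benzoyl, a different kind of change, so it offers no direct guide. Without such evidence, the step from compound 3 to compound 4 is expected to stay within the scatter, as a 1.0-fold lower number from compound 3 to compound 4 (0.01 log units; within the scatter). Compound 4 is therefore estimated to give about 33000 nM in this assay, within a range from 12000 nM to 90000 nM.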

Compound 4, half-maximal inhibitory concentration: 11300 nM
Beside the measured number, compound 4's estimate is 2.9-fold (0.47 log units) above it; measured number outside the range, below it.
By their numbers in this assay, from the lowest: compound 4; then compounds 1 and 3 (each within the scatter of the next). At a limit, above all of these: compound 2.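

In this assay, moving the fluorine, with 2-fluorophenyl in place of 4-fluorophenyl on the carbonyl carbon, gave a 3.0-fold lower number from compound 3 to compound 4 (0.47 log units; beyond the scatter), so compound 4 is a modestly stronger inhibitor than compound 3. Among the compounds shown here, the one earlier step exchanged benzyl for benzoyl and so altered the link to the oxygen, whereas this one keeps the same atoms and only joins them differently, showing that the place of a single fluorine on this aromatic ring can by itself move the number beyond the scatter. Nothing measured here explains why the 2-fluorophenyl compound gives the lower number.

The compounds shown leave open whether the step depends on fluorine itself or whether another small substituent in the same place, such as a chlorine atom, a methoxy group or an amine, would give a similar number. They also leave open whether the same exchange of 4-fluorophenyl for 2-fluorophenyl would move the number to a similar extent on a different core.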